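Trimethoxy and Hydroxy Variants of a Benzimidazole Biphenyl Series

This account rests on a few compounds, and the source may have more. Where it says the series, first, only, none or still open, it means among the compounds named here.

Compound 1 `COc1ccc(-c2ccc(-c3ccc(-c4nc5ccccc5[nH]4)cc3)cc2)cc1OC` is the parent. In a functional assay on COLO 205 cells (Homo sapiens) for inhibition, read by sulforhodamine B assay (a lower number here means a stronger inhibitor of growth, a higher number a weaker inhibitor of growth), compound 1 gives 41200 nM. Compound 2 `COc1cc(-c2ccc(-c3ccc(-c4nc5ccccc5[nH]4)cc3)cc2)cc(OC)c1OC` carries the change methoxy in place of hydrogen on an aromatic carbon and gives 8320 nM, the step being a 5.0-fold lower number from compound 1 to compound 2 (0.69 log units; beyond the scatter). Compound 3 `COc1ccc(-c2ccc(-c3ccc(-c4nc5c(O)cccc5[nH]4)cc3)cc2)cc1OC` carries hydroxy in place of hydrogen on an aromatic carbon and gives 1320 nM, the step being a 31-fold lower number from compound 1 to compound 3 (1.49 log units; beyond the scatter); compound 3 has the lowest number of the three, beyond the scatter against both others.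

Compound 4 `COc1cc(-c2ccc(-c3ccc(-c4nc5c(O)cccc5[nH]4)cc3)cc2)cc(OC)c1OC` is not yet measured. It differs from compound 3 by methoxy in place of hydrogen on an aromatic carbon, which is the same change as that from compound 1 to compound 2, on a core that differs by hydroxy in place of hydrogen on an aromatic carbon. For compound 4 a step of about a 4.4-fold lower number from compound 3 to compound 4 (0.64 log units; beyond the scatter) in this assay is expected, resting on the size of a 5.0-fold lower number from compound 1 to compound 2 (0.69 log units; beyond the scatter). That step is applied to the number that compound 3 gives, 1320 nM. Compound 4 is therefore estimated at 300 nM, with a likely range from 100 nM to 900 nM.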

Compound 4, concentration for 50% growth inhibition: 190 nM
For compound 4 the middle estimate is 1.6-fold (0.20 log units) above the measured one; the range from low to high includes it.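

In this assay the methoxy change gives a 6.9-fold lower number from compound 3 to compound 4 (0.84 log units; beyond the scatter) and keeps its size on the core carrying the hydroxy group: the same change on two cores in this assay, a 5.0-fold lower number (0.69 log units; beyond the scatter) from compound 1 to compound 2 and a 6.9-fold lower number (0.84 log units; beyond the scatter) from compound 3 to compound 4, 1.4-fold (0.15 log units) apart, within the scatter of two such steps.
The hydroxy change gives a 44-fold lower number from compound 2 to compound 4 (1.64 log units; beyond the scatter) and likewise keeps its size on the core of compound 2: the same change on two cores in this assay, a 31-fold lower number (1.49 log units; beyond the scatter) from compound 1 to compound 3 and a 44-fold lower number (1.64 log units; beyond the scatter) from compound 2 to compound 4, 1.4-fold (0.15 log units) apart, within the scatter of two such steps.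
Within the data shown here, each change is thus seen on only two cores in a single assay, which shows that the two changes add up within this set of compounds but does not show that either would carry over to any other core, nor why they add up.

The compounds shown leave open whether an amine or a carboxylic acid in place of the hydroxy would give a step of similar size. They also leave open whether a longer chain in place of methoxy would do so.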